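Chloro added to the shared core: compound 3 expected

The source may hold more compounds than are shown below. What is called first, only, known or untested is meant among the compounds shown, and "the series" means these compounds.

Measured in an ADME assay on HCT-116 cells (Homo sapiens) for cytotoxicity, read by MTT assay, with a stated time of 48 h, tested at 2 uM; a higher number here means a stronger effect of the compound at the concentration tested, a lower number a weaker effect:
compound 1, `O=C1C(=O)N(CC(CO)NCCCCNc2ccnc3cc(Cl)ccc23)c2ccccc21`: -5%
compound 2, `O=C1C(=O)N(CC(CO)NCCCNc2ccnc3cc(Cl)ccc23)c2ccccc21`: -12%

Compound 2 stands lowest of the two numbers, with compound 1 nearest and within the scatter, so no order between the two can be claimed. Compound 3, `O=C1C(=O)N(CC(CO)NCCCNc2ccnc3cc(Cl)ccc23)c2ccc(Cl)cc21`, is not yet measured. It differs from compound 2 by chloro in place of hydrogen on an aromatic carbon. Within the data shown here, no step between measured compounds is known, so the size of this change in this assay cannot be read from the data; with both measured numbers close to zero, no step beyond the scatter is expected in either direction. Compound 3 is expected to give -6%, between -25% and 15%, which means an expected step of a number 6 percentage points higher from compound 2 to compound 3 (within the scatter).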

Compound 3, a percentage reported as inhibition, at one concentration (the size of the read-out at that concentration, not a potency): 2%
Compound 3: middle estimate off by 8 percentage points, on the low side; measured number inside the range.
By their numbers in this assay, from the lowest: compounds 2, 1 and 3 (each within the scatter of the next, the first and the last beyond it).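

In this assay, among these compounds, chloro in place of hydrogen on an aromatic carbon, para to a fused ring, gives a number 14 percentage points higher from compound 2 to compound 3 (beyond the scatter) and is the first change with a readable step. The step is modest and all three numbers stay near zero, so this change moves the read-out only slightly at the concentration tested. Nothing measured here bears on the reason for this step.

On these data alone, whether a methoxy group or a nitrile at this position would move the number further remains open. Also open, as far as these compounds go, is whether chloro here gives a similar step on the chain of compound 1.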